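Dropping a Ring Methyl from a Bile Acid Receptor Antagonist

The source may hold more compounds than are shown below. What is called first, only, known or untested is meant among the compounds shown, and "the series" means these compounds.

Measured compounds:
compound 1 `CC(=O)N1CCC(C[C@@H](c2nc3ccc(C)cc3n2C)N2C(=O)CN(c3ccc(Oc4ccccc4)cc3)C2=O)CC1`: 0.2 nM
compound 2 `Cc1ccc2nc([C@H](CC3CCN(C(=O)C(C)C)CC3)N3C(=O)CN(c4ccc(Oc5ccccc5)cc4)C3=O)n(C)c2c1`: < 0.001 nM

In an assay on cells for antagonist activity at Bile acid receptor (Homo sapiens), read by a luciferase reporter, with a stated time of 24 h (a lower number here means a stronger inhibitor, a higher number a weaker inhibitor), compound 1 gives 0.2 nM. For compound 2 the assay reports only a limit, < 0.001 nM. Within the data shown here, compound 1 is thus the only compound with an actual number. Among the measured compounds shown here, the single measured step, an at least 200-fold lower number from compound 1 to compound 2 (2.30 log units; beyond the scatter), concerns the carbonyl group and not the ring. Compound 3 `CC(=O)N1CCC(C[C@@H](c2nc3ccccc3n2C)N2C(=O)CN(c3ccc(Oc4ccccc4)cc3)C2=O)CC1` differs from compound 1 by hydrogen in place of methyl on an aromatic carbon. For the measured compounds named here, no measured step covers this position, so only a small shift toward a weaker inhibitor is expected, a 2.0-fold higher number from compound 1 to compound 3 (0.30 log units; within the scatter). Compound 3 is therefore estimated at 0.4 nM, between 0.1 nM and 2 nM.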

Compound 3, half-maximal inhibitory concentration: 0.002 nM
Estimate against measurement, compound 3: 200-fold (2.30 log units) above, outside the stated range (below it).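

The ring methyl matters: with hydrogen in its place on the aromatic carbon, this assay shows a 100-fold lower number from compound 1 to compound 3 (2.00 log units; beyond the scatter). So the loss of a single carbon from this ring, and not only a change at the carbonyl, can move the number far beyond the scatter. Compound 2 has only a limit, which marks the edge of what is reported: the limit of < 0.001 nM in this assay, at which 1 of the 3 values shown sits.

Going by these compounds, what a chlorine, a methoxy or an amine would do on this carbon stays open. So does the effect of hydrogen here when combined with the isopropyl group of compound 2.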